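This account rests on a few compounds, and the source may have more. Where it says the series, first, only, none or still open, it means among the compounds named here.

Among the compounds with values here, compound 2 `CC(C)=CCC/C(C)=C/CC1Cc2c(OCCCNC(=O)c3cccs3)cc(=O)n(CCCO)c2CC1(C)C` gives 72.8% in a functional assay on PANC-1 cells (Homo sapiens) for inhibition, read by MTT assay, with a stated time of 24 h, tested at 10 uM (a higher number here means more inhibition at the concentration tested (going by the name of the read-out), a lower number less inhibition), the higher of the two numbers at hand; compound 1 `CC(C)=CCC/C(C)=C/CC1Cc2c(OCc3ccccc3)cc(=O)n(CCCO)c2CC1(C)C` gives 46.5%, and the sole step so far, a number 26.3 percentage points higher from compound 1 to compound 2 (beyond the scatter), came with phenyl giving way to the longer chain. Compound 3 `COc1cccc(NC(=O)Oc2cc(=O)n(CCCO)c3c2CC(C/C=C(\C)CCC=C(C)C)C(C)(C)C3)c1` carries the change ((3-methoxyphenyl)carbamoyl in place of 3-(((thiophen-2-yl)carbonyl)amino)propyl on an oxygen on an aromatic ring). Within the data shown here, no measured step bears on this change directly; the one step known moved away from a six-membered aromatic ring of carbon only on that oxygen, and compound 3 brings such a ring back, so a downward step is expected, a number 17.8 percentage points lower from compound 2 to compound 3 (beyond the scatter). Compound 3 is estimated at 55%, range 35% to 75%.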

Compound 3, a percentage reported as inhibition, at one concentration (the size of the read-out at that concentration, not a potency): 47%
For compound 3 the middle estimate is 8 percentage points above the measured one, and the stated range covers the measured number.
By their numbers in this assay, from the lowest: compounds 1 and 3 (each within the scatter of the next); then compound 2.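

In this assay, (3-methoxyphenyl)carbamoyl in place of 3-(((thiophen-2-yl)carbonyl)amino)propyl on this oxygen gives a number 25.8 percentage points lower from compound 2 to compound 3 (beyond the scatter) and does not hold the higher level. Set against benzyl, the same group gives a number 0.5 percentage points higher from compound 1 to compound 3 (within the scatter) and so does not separate from it; among these three compounds, only the thiophene-bearing chain stands apart. No evidence at hand explains this difference.

On these data alone, it remains open whether the thiophene ring, the amide or the propyl chain carries the higher number. A benzamide on the same propyl chain, or a terminal amine, would help separate these.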